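This account rests on a few compounds, and the source may have more. Where it says the series, first, only, none or still open, it means among the compounds named here.

Working notes on the series. The shared core is that of compound 1 `CCCCCCCCCCCCCCCCCC(=O)NCc1ccc(O)c(OC)c1`, a long saturated chain joined through an amide to the aromatic head. In an assay on HEK293 cells for antagonist activity at transient receptor potential cation channel subfamily V member 2 (Rattus norvegicus), read by fluorescence and calcium flux, with a stated time of 5 min (a lower number here means a stronger inhibitor, a higher number a weaker inhibitor), compound 1 gives > 10000 nM, which is a limit of the assay and not a number. Compound 1 therefore stands at the limit of > 10000 nM in this assay, at which 1 of the 2 values shown sits. Compound 2 `CCCCCCCC/C=C\CCCCCCCCSCCC(=O)NCc1ccc(O)c(OC)c1` carries a different chain, and in this assay compound 2 gives "not determined" (no result reported), so no number stands beside it. Compound 3 `CCCCCCCCCCCCCCCCCCCC(=O)NCc1ccc(O)c(OC)c1` differs from compound 1 only by ethyl in place of hydrogen on a saturated chain carbon, ten or more bonds along the chain from a carbonyl carbon. Within the data shown here, no step between measured compounds exists to size this change. Because compound 1 rests at the limit of > 10000 nM in this assay, at which 1 of the 2 values shown sits, the step that the limit leaves unreadable from compound 1 to compound 3 is expected to show no movement beyond the scatter, and a further limit is the likelier outcome. Compound 3 is expected to give 15000 nM in this assay, within 3000 nM to 60000 nM.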

Compound 3, half-maximal inhibitory concentration: > 10000 nM
Compound 3: a limit, no number; the forecaster's own chance of this, stated with the estimate: 75%; the middle value lies beyond the limit too.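

In this assay, among these compounds, compound 1 and compound 3 both rest at a limit and not a number, so no step between them can be read. The compounds shown leave open whether any saturated chain on the shared core gives a readable value in this assay at all.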